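The source may report more compounds than this note shows. Statements on the series, on what has been measured and on what is new or still open speak of the compounds shown alone.

Measured so far in an assay on BTI cells for inhibition of Amine oxidase [flavin-containing] B (Homo sapiens), read by fluorescence and Amplex Red, with a stated time of 15 min; on this read-out lower numbers stand for stronger inhibition and higher numbers for weaker inhibition:
- compound 1, `CC(=O)N1N=C(c2ccc([N+](=O)[O-])cc2)O[C@@H]1c1ccc(Cl)c(Cl)c1`: 7.61 nM
- compound 2, `CC(=O)N1N=C(c2ccncc2)OC1c1ccc(Cl)c(Cl)c1`: 69400 nM

Within this pair compound 2 stands at the higher number. Compound 1 gives 7.61 nM and compound 2 gives 69400 nM, a gap well beyond the scatter of repeated measurements; no stepwise comparison between the two is available, so only the two values themselves are on hand.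

Compound 3, `CC(=O)N1N=C(c2ccc(C)cc2)OC1c1ccc(Cl)c(Cl)c1`, differs from compound 2 in one place: 4-methylphenyl in place of pyridin-4-yl on a carbon with a double bond to nitrogen. A six-membered aromatic ring of carbon only now sits on the carbon with a double bond to nitrogen, as in compound 1, though with a different substituent on that ring.

For compound 3 the expected step from the number of compound 2 is a marked drop, a 350-fold lower number from compound 2 to compound 3 (2.54 log units; beyond the scatter), toward stronger inhibition, because compound 1 with a carbon-only ring at this carbon gives 7.61 nM in this assay. The estimate for compound 3 in this assay is 200 nM, with a range from 20 nM to 3000 nM.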

Compound 3, half-maximal inhibitory concentration: 19.4 nM
Compound 3: the middle estimate sits 10-fold (1.01 log units) above what was measured; measured number below the stated range.
By their numbers in this assay, from the lowest: compound 1; then compound 3; then compound 2.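

With the rest of the core held constant, this position alone gives a very large change in this assay: 4-methylphenyl in place of pyridin-4-yl gives a 3600-fold lower number from compound 2 to compound 3 (3.55 log units; beyond the scatter). This is the first single-place comparison in the series, so the carbon with a double bond to nitrogen is now shown to be highly sensitive to the group it carries. The swap removes the ring nitrogen and adds the methyl group together, so the step cannot be divided between the two, and no measurement on hand accounts for its size.

Open, on these data alone, is how an unsubstituted phenyl ring would read at this carbon, which would separate those two parts of the change. Also open, as far as these compounds go, is how far the ring tolerates other groups in place of the methyl group, such as an amine or a carboxylic acid.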